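Changing the carbonyl substituent of compound 3

This account rests on a few compounds, and the source may have more. Where it says the series, first, only, none or still open, it means among the compounds named here.

In a functional assay on NCI-H1975 cells (Homo sapiens) for antiproliferative activity, read by MTT assay, with a stated time of 72 h (on this read-out lower numbers stand for stronger inhibition and higher numbers for weaker inhibition), compound 1 (`COc1ccc(C(=O)Nc2cc(Nc3nccc(-c4cn(C)c5ccccc45)n3)c(OC)cc2F)nc1`) gives 16800 nM, compound 2 (`COc1cc(N(C)CCN(C)C)c(NC(=O)c2ccncc2OC)cc1Nc1nccc(-c2cn(C)c3ccccc23)n1`) gives 1010 nM and compound 3 (`COc1ccc(C(=O)Nc2cc(Nc3nccc(-c4cn(C)c5ccccc45)n3)c(OC)cc2N(C)C)nc1`) gives 2130 nM. Compound 3 thus holds the middle of the three numbers, above compound 2 and below compound 1.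

Compound 4 (`COc1cc(N(C)C)c(NC(=O)c2nccn2C)cc1Nc1nccc(-c2cn(C)c3ccccc23)n1`) has yet to be measured. Its difference from compound 3 is this: 1-methyl-1H-imidazol-2-yl in place of 5-methoxypyridin-2-yl on a carbonyl carbon. In short, 1-methyl-1H-imidazol-2-yl stands in place of 5-methoxypyridin-2-yl on a carbonyl carbon.

For the measured compounds named here, the one measured single-place step is a 7.9-fold lower number from compound 1 to compound 3 (0.90 log units; beyond the scatter). It is modest in size and concerns dimethylamino in place of fluoro on an aromatic carbon, so it says nothing directly about the carbonyl substituent. Compound 2, at 1010 nM, also carries another group on the carbonyl but differs from compound 3 elsewhere too, so it cannot isolate this change. Going by the values given here, no measured step covers this place, and neither direction is favoured by the data. No step beyond the scatter is therefore expected in this assay. The expected change is a 1.1-fold lower number from compound 3 to compound 4 (0.05 log units; within the scatter). For compound 4 the estimated value is 1900 nM, with an expected range of 550 nM to 6500 nM.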

Compound 4, half-maximal inhibitory concentration: 2880 nM
Estimate against measurement, compound 4: 1.5-fold (0.18 log units) below; measured number inside the range.
By their numbers in this assay, from the lowest: compound 2; then compounds 3 and 4 (each within the scatter of the next); then compound 1.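

In this assay the carbonyl substituent now has its first direct reading, a 1.4-fold higher number from compound 3 to compound 4 (0.13 log units; within the scatter), so in the background of compound 3 the 5-methoxypyridin-2-yl and 1-methyl-1H-imidazol-2-yl groups cannot be told apart on this read-out. This holds even though the swap replaces a six-membered aromatic ring with 1 hetero atom by a five-membered aromatic ring with 2 hetero atoms, with fewer heavy atoms and the same number of hydrogen-bond acceptors, so these differences in ring size and hetero atom count carry no step beyond the scatter in this single pair. Nothing at hand offers any explanation for this result.

Going by these compounds, it remains open whether a non-aromatic group such as piperidin-4-yl, or an acyclic chain bearing a primary amine, on the carbonyl carbon would give a step beyond the scatter. Also open, on these data alone, is whether the match between these two groups persists when the dimethylamino group of compound 3 and compound 4 gives way to fluoro or to a morpholine ring.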